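Salicylanilide series: removing the pyridin-4-yl group

A few compounds are considered here, and "the series" means these few. Any claim that something is new, unique, unknown or untested is made for them only; others in the source may bear on it.

Measured so far:
- compound 1, `N#Cc1ccc(NC(=O)c2cc(-c3ccncc3)ccc2O)cc1`: in a functional assay on KG-1 cells (Homo sapiens) for cytotoxicity, read by luminescence and CellTiter-Glo, with a stated time of 3 days (a higher number here means a weaker inhibitor, a lower number a stronger inhibitor), compound 1 gives 7990 nM
- compound 2, `O=C(Nc1ccc(Cl)cc1Cl)c1ccc2cccnc2c1O`: in this assay compound 2 gives 3560 nM

Compound 1 holds the higher of the two numbers; compound 2 stands below it, beyond the scatter. Compound 3, `N#Cc1ccc(NC(=O)c2ccccc2O)cc1`, is the next step from compound 1: hydrogen in place of pyridin-4-yl on an aromatic carbon. Within the data shown here, no pair of measured compounds shows the effect of removing the pyridin-4-yl group, so the step is unsized by the data. The expectation is a move toward a weaker inhibitor, with a step of a 2.5-fold higher number from compound 1 to compound 3 (0.40 log units; beyond the scatter). Compound 3 is expected near 20000 nM, within 7000 nM to 60000 nM.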

Compound 3, half-maximal inhibitory concentration: 5370 nM
For compound 3 the middle estimate is 3.7-fold (0.57 log units) above the measured one; measured number outside the range, below it.
By their numbers in this assay, from the lowest: compounds 2, 3 and 1 (each within the scatter of the next, the first and the last beyond it).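

Removing pyridin-4-yl from the aromatic carbon para to a hydroxy group is now sized: in this assay the change gives a 1.5-fold lower number from compound 1 to compound 3 (0.17 log units; within the scatter) and does not separate the two compounds. On the core of compound 1, pyridin-4-yl at this position is therefore not needed for the activity read here. No available measurement bears on this result.

As far as these compounds go, whether an amine, a carboxylic acid or a methoxy group on this carbon would separate from compound 3 remains open. Also open, from the compounds shown here alone, is whether pyridin-4-yl would count for as little on other cores.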